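Amide change on the ethyl ester arm of the series

The compounds below may be only part of what the source reports. "The series", "measured", "known", "first", "only" and "open" are said of these compounds alone.

Two compounds of the series have numbers in a functional assay on Maver1 cells (Homo sapiens) for inhibition, read by luminescence and CellTiter-Glo, with a stated time of 72 h; a lower number here means a stronger inhibitor, a higher number a weaker inhibitor. Compound 1 `O=C(CCl)Nc1ccc(Cn2nc(-c3ccc(Oc4ccccc4)cc3)cc2CO)cc1` gives 400 nM in this assay. Compound 2 `CCOC(=O)c1cc(-c2ccc(Oc3ccccc3)cc2)nn1Cc1cccc(NC(=O)CCl)c1` gives 500 nM in this assay; this is the higher of the two numbers, but its gap to compound 1 lies within the scatter, so the two stand level. Compound 3 `C/C=C/C(=O)Nc1ccc(Cn2nc(-c3ccc(Oc4ccccc4)cc3)cc2C(=O)OCC)cc1` has not been measured. It differs from compound 2 in one place: 4-(((prop-1-en-1-yl)carbonyl)amino)phenyl in place of 3-(((chloromethyl)carbonyl)amino)phenyl on a saturated chain carbon bound to an aromatic nitrogen. Among the measured compounds shown here, both measured compounds carry a chloromethyl-carbonyl amide, and no measured pair shows the effect of replacing it, so the expected size of the step rests on the structural change alone, with no step in the data to anchor it. A moderate step toward a higher number is expected, a 2.4-fold higher number from compound 2 to compound 3 (0.38 log units; beyond the scatter), beyond the scatter but not large. Compound 3 is expected at 1200 nM, within a range from 300 nM to 5000 nM.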

Compound 3, half-maximal inhibitory concentration: > 60000 nM
Compound 3 was reported as a limit (the forecaster's own chance of this, stated with the estimate: 10%); at least 50-fold (1.69 log units) between middle value and limit.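

Compound 3 stands only as a limit, > 60000 nM, in this assay. Among the compounds shown here, replacing 3-(((chloromethyl)carbonyl)amino)phenyl with 4-(((prop-1-en-1-yl)carbonyl)amino)phenyl on a saturated chain carbon bound to an aromatic nitrogen gives an at least 120-fold higher number from compound 2 to compound 3 (2.07 log units; beyond the scatter), the first step and the first sign that the number responds strongly to a change in this place. The step is a minimum and its full size cannot be read: the limit of > 60000 nM in this assay, at which 1 of the 3 values shown sits.

The exchange alters both the amide group and its numbered place on the phenyl ring, so the compounds shown do not separate the two contributions. Also open, on these data alone, is how a 3-(((prop-1-en-1-yl)carbonyl)amino)phenyl, a 4-(((chloromethyl)carbonyl)amino)phenyl or a plain acetyl amide would read on the ethyl ester arm.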